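Chloro in place of methyl on compound 1

This account rests on a few compounds, and the source may have more. Where it says the series, first, only, none or still open, it means among the compounds named here.

Values so far in an ADME assay on a cell-free system (plasma, Homo sapiens) for protein binding
Compound 1 `Cc1ccc([C@@H](C)Oc2cc3onc(CCC(=O)O)c3cc2Cl)nc1` gives 99.7%
Compound 2 `O=C(O)CCn1c(=O)oc2cc(OCc3ccccn3)c(Cl)cc21` gives 92.6%

Of the two, compound 1 has the lower unbound fraction, and the gap to compound 2 lies beyond the scatter. Compound 3 `C[C@@H](Oc1cc2onc(CCC(=O)O)c2cc1Cl)c1ccc(Cl)cn1` has not yet been measured. It differs from compound 1 by chloro in place of methyl on an aromatic carbon, which reads as 5-methylpyridin-2-yl to 5-chloropyridin-2-yl. Going by the values given here, no measured pair shows this change, so only a cautious expectation is possible, with no shift beyond the scatter in this assay in either direction. The expected step is no change at the digits printed from compound 1 to compound 3 (within the scatter) and would stay within the scatter. For compound 3 the estimated value is 99.7% with an expected range of 99.2% to 99.9% around it.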

Compound 3, plasma protein binding in the plasma assay: 99.8%
Compound 3: the middle estimate sits 1.5-fold (0.18 log units) (unbound fraction) above what was measured; low and high end bracket the measured number.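

Chloro in place of methyl, on an aromatic carbon two atoms from the ring nitrogen, is the only single-place change shown in the plasma assay, and it gives a 1.5-fold lower unbound fraction from compound 1 to compound 3 (0.18 log units; within the scatter). In a physicochemical assay for solubility, with a stated time of 24 h (a lower number here means a less soluble compound, a higher number a more soluble compound), compound 1 gives > 860 ug/mL, which is a limit of the assay. In the physicochemical assay compound 3 gives > 620 ug/mL, also a limit, so the step between the two cannot be read.

On these data alone, whether an amine or a methoxy group at this position would shift the unbound fraction beyond the scatter remains open.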